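This account rests on a few compounds, and the source may have more. Where it says the series, first, only, none or still open, it means among the compounds named here.

Working notes on the series, read in a physicochemical assay for solubility, in phosphate buffer, with a stated time of 18 h; on this read-out higher numbers stand for higher solubility and lower numbers for lower solubility. Compound 1 (`Cc1nc(C(C)(C)C)nc2nc(N)c(C#N)c(N)c12`) gives 37000 nM, compound 2 (`CC(C)(C)c1nc(CCCCC#N)c2c(N)c(C#N)c(N)nc2n1`) gives 16000 nM and compound 3 (`Cc1c[nH]c(-c2nc(C(C)(C)C)nc3nc(N)c(C#N)c(N)c23)n1`) gives 5000 nM. Compound 3 thus holds the lowest of the three numbers, with compound 2 nearest and compound 1 furthest.

The next compound to read is compound 4 (`CC(C)(C)c1nc(-c2ncco2)c2c(N)c(C#N)c(N)nc2n1`), not yet measured. The change is 1,3-oxazol-2-yl in place of 4-methyl-1H-imidazol-2-yl on an aromatic carbon, meta to a tert-butyl group.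

Among the compounds with values here, no measured step exchanges one five-membered aromatic ring for another. The closest evidence is the entry of 4-methyl-1H-imidazol-2-yl at this carbon, seen as a 7.4-fold lower number from compound 1 to compound 3 (0.87 log units; beyond the scatter) and as a 3.2-fold lower number from compound 2 to compound 3 (0.51 log units; beyond the scatter). The remaining step, a 2.3-fold lower number from compound 1 to compound 2 (0.36 log units; beyond the scatter), is also modest. All three lie beyond the scatter, so a modest step is a fair expectation, and a larger one has no support in these data. The direction is only weakly supported: it rests on compound 3 standing lowest at 5000 nM, which leaves more of the measured range above it than below.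

A modest step toward a higher number is expected in this assay, estimated as a 2.2-fold higher number from compound 3 to compound 4 (0.34 log units; beyond the scatter). The estimate for compound 4 is 11000 nM, with an expected range from 4000 nM to 30000 nM.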

Compound 4, solubility: 50000 nM
Compound 4: the middle estimate sits 4.5-fold (0.66 log units) below what was measured; measured number above the stated range.
By their numbers in this assay, from the lowest: compound 3; then compound 2; then compounds 1 and 4 (each within the scatter of the next).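

In this assay, within the data shown here, the exchange of one five-membered aromatic ring for another on this aromatic carbon, meta to a tert-butyl group, gives a 10-fold higher number from compound 3 to compound 4 (1.00 log units; beyond the scatter), the largest step so far. A five-membered aromatic ring at this carbon therefore does not by itself go with the lowest number: compared with 4-cyanobutyl, 1,3-oxazol-2-yl gives a 3.1-fold higher number from compound 2 to compound 4 (0.49 log units; beyond the scatter), while compared with methyl it gives a 1.4-fold higher number from compound 1 to compound 4 (0.13 log units; within the scatter), which lies within the scatter, so compound 1 and compound 4 cannot be ordered. No measurement shown bears on why the two rings differ so far in this read-out.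

The step from compound 3 to compound 4 changes the ring atoms, the methyl group and the hydrogen-bond donor count together, so the compounds shown leave open which of these changes carries it. A 1H-imidazol-2-yl without the methyl group, a 4-methyl-1,3-oxazol-2-yl or a 1,3-thiazol-2-yl on the same carbon would separate these changes, and an open-chain amine or a carboxylic acid there remains an open case.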